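The source may report more compounds than this note shows. Statements on the series, on what has been measured and on what is new or still open speak of the compounds shown alone.

Compound 1 `Cc1cc(-c2c(C)nn(C)c2C)ccc1-c1nnc(N(C)Cc2ccc3nccn3c2)o1` is the reference point of this set. In an assay on COS-7 cells for inhibition of tyrosine-protein kinase receptor UFO (Homo sapiens), read by ELISA, with a stated time of 1 h (on this read-out lower numbers stand for stronger inhibition and higher numbers for weaker inhibition), compound 1 gives 398 nM, the lowest of the two numbers shown. Compound 2 `Cc1cc(-c2c(C)n[nH]c2C)ccc1-c1nnc(N(C)Cc2ccc3nccn3c2)o1` gives 15800 nM in this assay, and the step of a 40-fold higher number from compound 1 to compound 2 (1.60 log units; beyond the scatter) rests on hydrogen in place of methyl on an aromatic nitrogen. Compound 3 `Cc1cc(-c2c(C)nn(C(F)F)c2C)ccc1-c1nnc(N(C)Cc2ccc3nccn3c2)o1` shows in this assay only a limit of the assay, > 10000 nM. The step of an at least 25-fold higher number from compound 1 to compound 3 (1.40 log units; beyond the scatter) rests on difluoromethyl in place of methyl on an aromatic nitrogen.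

Compound 4 `Cc1cc(-c2c(C)nn(C)c2C)ccc1-c1nnc(N(C)Cc2ccc3ncc(-c4cnn(C)c4)n3c2)o1` differs from compound 1 by 1-methyl-1H-pyrazol-4-yl in place of hydrogen on an aromatic carbon. Going by the values given here, both measured steps change the substituent on the aromatic nitrogen of a different ring, and neither touches the aromatic carbon where the 1-methyl-1H-pyrazol-4-yl enters; so no measured step bears directly on this change. The step of a 1.0-fold higher number from compound 1 to compound 4 (0.00 log units; within the scatter) is therefore expected to stay within the scatter, in no particular direction. Compound 4 is estimated in this assay at 400 nM, with a range from 130 nM to 1250 nM.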

Compound 4, half-maximal inhibitory concentration: 63.1 nM
The estimate for compound 4 lay 6.3-fold (0.80 log units) above the measured number; measured number below the stated range.
By their numbers in this assay, from the lowest: compound 4; then compound 1; then compound 2.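

In this assay, the step of a 6.3-fold lower number from compound 1 to compound 4 (0.80 log units; beyond the scatter) is the only one shown that leads to a lower number, while the steps away from compound 1 to compound 2 and compound 3, both on an aromatic nitrogen of a different ring, lead to higher numbers. It shows that the aromatic carbon of the five-membered aromatic ring, part of a fused or bridged system of two rings, can carry 1-methyl-1H-pyrazol-4-yl in place of hydrogen with a modest gain. Nothing given here speaks to the cause of this step.

Among the compounds shown, this position holds only hydrogen and 1-methyl-1H-pyrazol-4-yl, so it remains open how a methyl, a morpholine or a carboxylic acid would fare there. Whether the same group would also lower the number on the cores of compound 2 and compound 3 is open as well.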